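Cytotoxicity of a cyanophenyl triazole analogue, estimated

The source may report more compounds than this note shows. Statements on the series, on what has been measured and on what is new or still open speak of the compounds shown alone.

Compound 3 `CC(C)=CCC1=C(OCc2cn(-c3ccc(S(N)(=O)=O)cc3)nn2)C(=O)c2ccccc2C1=O` in an ADME assay on HepG2 cells (Homo sapiens) for cytotoxicity, read by MTT assay, with a stated time of 24 h (a higher number here means that more compound is tolerated, a lower number that less compound is tolerated), gives 483000 nM, the second highest of the three measured numbers. For the measured compounds named here, compound 1 `CC(C)=CCC1=C(OCc2cn(Cc3ccccn3)nn2)C(=O)c2ccccc2C1=O` gives 658000 nM, and compound 2 `CC(C)=CCC1=C(OCc2cn(-c3cccc(F)c3)nn2)C(=O)c2ccccc2C1=O` gives 265000 nM; both a 1.4-fold lower number from compound 1 to compound 3 (0.13 log units; within the scatter) and a 1.8-fold higher number from compound 2 to compound 3 (0.26 log units; within the scatter) lie within the scatter, while a 2.5-fold lower number from compound 1 to compound 2 (0.39 log units; beyond the scatter) is the only step beyond it. Compound 4 `CC(C)=CCC1=C(OCc2cn(-c3ccc(C#N)cc3)nn2)C(=O)c2ccccc2C1=O` differs from compound 3 by cyano in place of sulfamoyl on an aromatic carbon. The step that bears most directly on this change is the swap of one aryl substituent for another in a 1.8-fold higher number from compound 2 to compound 3 (0.26 log units; within the scatter), and it stayed within the scatter, so no step beyond the scatter is expected for a 1.2-fold lower number from compound 3 to compound 4 (0.08 log units; within the scatter). Compound 4 is therefore estimated at 400000 nM, with a range from 200000 nM to 800000 nM.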

Compound 4, half-maximal cytotoxic concentration: 707000 nM
Compound 4: middle estimate off by 1.8-fold (0.25 log units), on the low side; measured number inside the range.
By their numbers in this assay, from the lowest: compounds 2, 3, 1 and 4 (each within the scatter of the next, the first and the last beyond it).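

Replacing sulfamoyl with cyano at this position gives a 1.5-fold higher number from compound 3 to compound 4 (0.17 log units; within the scatter) in this assay, so the two groups cannot be told apart here. The step of a 1.1-fold higher number from compound 1 to compound 4 (0.03 log units; within the scatter) likewise stays within the scatter, whereas a 2.7-fold higher number from compound 2 to compound 4 (0.43 log units; beyond the scatter) goes beyond it, making this the second such step and, like the first, one involving compound 2. Nothing in the available evidence accounts for these steps.

On these data alone, it remains open whether a carboxylic acid or an amine at this position would also stay within the scatter. Also open, as far as these compounds go, is how cyano would read in place of the fluoro group of compound 2, with the ring position kept the same.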